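Dropping a Chloro Group: Three Measured, One Expected

The compounds below may be only part of what the source reports. "The series", "measured", "known", "first", "only" and "open" are said of these compounds alone.

Of the compounds shown here, three built on a shared core have been tested in an ADME assay for permeability, using PAMPA, with a stated time of 3 h; a higher number here means that the compound crosses the layer faster, a lower number that the compound crosses the layer more slowly. Compound 1 `O=C(Nc1ccc([N+](=O)[O-])cc1)c1cc(Cl)ccc1O` gives 12.4 10^-6 cm/s. Compound 2 `O=C(Nc1ccc([N+](=O)[O-])c(Cl)c1)c1cc(Cl)ccc1O` gives 12.3 10^-6 cm/s, and compound 3 `O=C(Nc1ccc(F)c(Cl)c1)c1cc(Cl)ccc1O` gives 11.5 10^-6 cm/s. All three numbers sit close together, with no gap among them beyond the usual scatter. Compound 4 `O=C(Nc1ccc(F)cc1)c1cc(Cl)ccc1O` has not yet been measured in this assay.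

The core of compound 3 differs from the core of compound 2 by fluoro in place of nitro on an aromatic carbon; that change produced a 1.1-fold lower number from compound 2 to compound 3 (0.03 log units; within the scatter). From compound 2 to compound 1 the change is hydrogen in place of chloro on an aromatic carbon, and the step was a 1.0-fold higher number from compound 2 to compound 1 (0.00 log units; within the scatter). From compound 3 to compound 4 the change is hydrogen in place of chloro on an aromatic carbon. In both pairs a chloro group leaves and hydrogen enters, yet the surroundings are not identical: in the measured pair the site is ortho to a nitro group (3 heavy atoms), while in the new pair it is ortho to a fluoro group (1 heavy atom). The two changes are therefore the same kind of change, not the same change.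

The measured removal of chloro left the number essentially unmoved, as a 1.0-fold higher number from compound 2 to compound 1 (0.00 log units; within the scatter) shows. Resting on that single observation, the expected step from compound 3 to compound 4 in this assay is a 1.0-fold higher number from compound 3 to compound 4 (0.01 log units; within the scatter). Compound 4 is accordingly estimated at 11.8 10^-6 cm/s, with a likely range from 7.5 10^-6 cm/s to 18 10^-6 cm/s.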

Compound 4, apparent permeability: 18.2 10^-6 cm/s
Estimate against measurement, compound 4: 1.5-fold (0.19 log units) below, outside the stated range (above it).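

In this assay, hydrogen in place of chloro gave a 1.6-fold higher number from compound 3 to compound 4 (0.20 log units; within the scatter), and this step agrees with the earlier one on the other core, as far as two steps can tell: the same change on two cores in this assay, a 1.0-fold higher number (0.00 log units; within the scatter) from compound 2 to compound 1 and a 1.6-fold higher number (0.20 log units; within the scatter) from compound 3 to compound 4, 1.6-fold (0.20 log units) apart, within the scatter of two such steps. Fluoro in place of nitro, now read on the pair that carries hydrogen at the chloro site, gave a 1.5-fold higher number from compound 1 to compound 4 (0.17 log units; within the scatter), and this also agrees with its earlier counterpart: the same change on two cores in this assay, a 1.1-fold lower number (0.03 log units; within the scatter) from compound 2 to compound 3 and a 1.5-fold higher number (0.17 log units; within the scatter) from compound 1 to compound 4, 1.6-fold (0.20 log units) apart, within the scatter of two such steps. So within these four compounds, each change carried from one core to the other with no difference beyond the scatter, but one pair of steps per change cannot prove that the steps are equal, and no step here stands out from the scatter as a real effect of either change.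

The compounds shown leave open whether the same would hold for other groups on that aromatic carbon, such as a methyl group, a methoxy group or an amine, or for a carboxylic acid in place of nitro. From the compounds shown here alone, all four compounds also share the same amide link and the same chloro- and hydroxyl-bearing ring, so it remains open whether either change would carry over to a core with a different link or ring.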